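A benzyl swap on the shared core

The compounds below may be only part of what the source reports. "The series", "measured", "known", "first", "only" and "open" are said of these compounds alone.

Measured in a functional assay on A-431 cells (Homo sapiens) for inhibition, read by sulforhodamine B assay, with a stated time of 2 days; a lower number here means a stronger inhibitor of growth, a higher number a weaker inhibitor of growth:
Compound 1 `CC1=C(C(=O)Nc2ccc(C)cc2)C(c2ccc(O)cc2O)NC(SCc2ccccc2)=N1`: 20800 nM
Compound 2 `CC1=C(C(=O)Nc2cccc([N+](=O)[O-])c2)C(c2ccc(O)cc2O)NC(SCc2ccccc2)=N1`: > 100000 nM (a limit of the assay, not a number)
Compound 3 `CC1=C(C(=O)Nc2ccc(C)cc2)C(c2ccc(O)cc2O)NC(NCc2ccccc2)=N1`: 42700 nM

Of the two actual numbers, compound 3 holds the higher one, 42700 nM. The gap to its nearest neighbour is a 2.1-fold higher number from compound 1 to compound 3 (0.31 log units; beyond the scatter), which makes it the weaker growth inhibitor of that pair by a modest margin. Compound 2 gives only a limit, > 100000 nM, as does (the limit of > 100000 nM in this assay, at which 1 of the 3 values shown sits).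

Compound 4 `CC1=C(C(=O)Nc2ccc(C)cc2)C(c2ccc(O)cc2O)NC(Nc2ccc([N+](=O)[O-])cc2Cl)=N1` has 2-chloro-4-nitrophenyl in place of benzyl on an amine nitrogen. For the measured compounds named here, no measured step makes this exact change, so two steps serve as indirect guides. The first, a 2.1-fold higher number from compound 1 to compound 3 (0.31 log units; beyond the scatter), altered the same side of the molecule and moved the number modestly upward. The second, an at least 4.8-fold higher number from compound 1 to compound 2 (0.68 log units; beyond the scatter), brought in a 3-nitrophenyl group at the amide-type nitrogen, a different place, and also moved the number upward, by at least a modest amount. Both point towards weaker inhibition, so a modest upward step is expected, and a reading that reaches only the limit remains possible. The expected change is a 1.4-fold higher number from compound 3 to compound 4 (0.15 log units; within the scatter). Compound 4 is estimated at 60000 nM, with an expected range of 20000 nM to 100000 nM.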

Compound 4, concentration for 50% growth inhibition: 31900 nM
Compound 4: the middle estimate sits 1.9-fold (0.27 log units) above what was measured; low and high end bracket the measured number.
By their numbers in this assay, from the lowest: compounds 1, 4 and 3 (each within the scatter of the next, the first and the last beyond it). At a limit, above all of these: compound 2.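

In this assay, the amine nitrogen takes 2-chloro-4-nitrophenyl in place of benzyl with a 1.3-fold lower number from compound 3 to compound 4 (0.13 log units; within the scatter) as the result, so this aromatic group and benzyl cannot be told apart at this position. Measured against the benzylsulfanyl group, (2-chloro-4-nitrophenyl)amino gives a 1.5-fold higher number from compound 1 to compound 4 (0.19 log units; within the scatter) and so stays level with it, whereas benzylamino gave a 2.1-fold higher number from compound 1 to compound 3 (0.31 log units; beyond the scatter) and lay beyond the scatter. A nitrophenyl group on this side therefore does not repeat the upward step seen at the amide-type nitrogen, an at least 4.8-fold higher number from compound 1 to compound 2 (0.68 log units; beyond the scatter) in that case, and nothing in the data shown accounts for the difference between the two places.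

The compounds shown leave open how a plain phenyl, or a phenyl carrying only the chlorine or only the nitro group, would read on this amine nitrogen, so the two substituents cannot yet be separated. They also leave open whether a saturated amine such as morpholine or a simple butyl chain would be tolerated here, and whether any change at this nitrogen could offset the 3-nitrophenyl group on the amide.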